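The source may hold more compounds than are shown below. What is called first, only, known or untested is meant among the compounds shown, and "the series" means these compounds.

Compound 1 `O=C(Nc1ccc(Cl)c(-c2nnc3c(Cl)cccn23)c1)c1ccccc1` gives in a functional assay on T47D cells (Homo sapiens) for antiproliferative activity, read by MTT assay, with a stated time of 72 h (a lower number here means a stronger inhibitor, a higher number a weaker inhibitor), a value that is a limit of the assay, > 100000 nM.
Compound 2 `O=C(Nc1ccc(Cl)c(-c2nnc3c(Cl)cccn23)c1)c1ccc(Cl)cc1` gives in this assay a value that is also a limit, > 100000 nM.
Compound 3 `Cc1cc(Cl)ccc1C(=O)Nc1ccc(Cl)c(-c2nnc3c(Cl)cccn23)c1` gives in this assay a value that is again a limit, > 100000 nM.

Compound 3 therefore stands nowhere readable on the scale: its value is a limit, and every other value shown is the same limit, (the limit of > 100000 nM in this assay, at which 3 of the 3 values shown sit). The three steps between the measured compounds, a step that the two limits leave unreadable from compound 1 to compound 2, a step that the two limits leave unreadable from compound 1 to compound 3 and a step that the two limits leave unreadable from compound 2 to compound 3, are all of unreadable size for the same reason, so none of them shows whether a change on the carbonyl carbon of the amide moves the number at all.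

Compound 4 `O=C(Nc1ccc(Cl)c(-c2nnc3c(Cl)cccn23)c1)c1ccccn1` differs from compound 3 in one place: pyridin-2-yl in place of 4-chloro-2-methylphenyl on a carbonyl carbon. Among the measured compounds shown here, no measured step involves a pyridin-2-yl group, and the steps that do touch the group on the carbonyl carbon are unreadable. For the measured compounds named here, the only guidance is that three varied groups in that position all leave the value at the limit, so the expectation for compound 4 is a step of a number no higher from compound 3 to compound 4 (the limit leaves the size open) in this assay, most likely another limit rather than a number. The estimate for compound 4 is 100000 nM, with a range from 30000 nM to 300000 nM.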

Compound 4, half-maximal inhibitory concentration: > 100000 nM
Compound 4: no number, only a limit; the forecaster's own chance of this, stated with the estimate: 85%; the middle value lies on the limit itself.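

Compound 4 gives only a limit of the assay, > 100000 nM. Its steps to compound 1, compound 2 and compound 3 therefore cannot be read, because all the values share one limit: the limit of > 100000 nM in this assay, at which 4 of the 4 values shown sit.

The compounds shown leave open whether any group on the carbonyl carbon changes the result in this assay at all.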